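Phenyl-to-pyrimidinyl swap on the urea of compound 2

The compounds below may be only part of what the source reports. "The series", "measured", "known", "first", "only" and "open" are said of these compounds alone.

Two ureas have been measured in a functional assay (aorta) for inhibition, with Rattus norvegicus as the target; on this read-out lower numbers stand for stronger inhibition and higher numbers for weaker inhibition. Compound 1 `CC1(C)CCN(C(=O)Nc2ccccc2)c2cc(C#N)ccc21` holds the urea nitrogen inside a fused bicyclic core and gives 6700000 nM in this assay. Compound 2 `CC(C)(C)c1ccc(C#N)cc1NC(=O)Nc1ccccc1` carries an open tert-butyl group beside the urea on the same nitrile-bearing ring; in this assay compound 2 gives 1700000 nM, the lower of the two numbers, and its gap to compound 1 lies beyond the usual scatter. Both values are very high on this read-out, so inhibition is weak across the pair.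

Compound 3 `CC(C)(C)c1ccc(C#N)cc1NC(=O)Nc1cncnc1` keeps the open core of compound 2 and differs only at the far end of the urea: pyrimidin-5-yl in place of phenyl on an amide-type nitrogen. Among the measured compounds shown here, no measured pair contains this exchange. Its direction therefore cannot be read off from the measured compounds. The expectation is that the step from compound 2 to compound 3 stays within the scatter, with a slight lean towards a higher number, giving a 1.5-fold higher number from compound 2 to compound 3 (0.17 log units; within the scatter). For compound 3 in this assay the estimate is 2500000 nM, with a range from 800000 nM to 8000000 nM.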

Compound 3, half-maximal inhibitory concentration: 12400000 nM
Compound 3: the middle estimate sits 5.0-fold (0.70 log units) below what was measured; the whole stated range lies below it.
By their numbers in this assay, from the lowest: compound 2; then compounds 1 and 3 (each within the scatter of the next).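

In this assay, the far end of the urea proves to be a position where a single exchange registers: pyrimidin-5-yl in place of phenyl on an amide-type nitrogen gives a 7.3-fold higher number from compound 2 to compound 3 (0.86 log units; beyond the scatter), a shift in the direction of weaker inhibition. Until now, the only comparison in the series was between compound 1 and compound 2, which differ in the core, so nothing had shown how this end of the urea responds; the heavy-atom count stays the same across the exchange, while 2 ring carbons give way to 2 ring nitrogens and the count of hydrogen-bond acceptors goes from 0 to 2. No supporting measurement bears on why the number rises, so this one step records a size and direction and offers no explanation.

The compounds shown leave open whether the step belongs to pyrimidin-5-yl alone or would also appear with a pyridin-3-yl or a cyclohexyl group on the same nitrogen. They also leave open whether the same exchange would give a similar step on the core of compound 1.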